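The source may report more compounds than this note shows. Statements on the series, on what has been measured and on what is new or still open speak of the compounds shown alone.

Working notes on the series.

Three compounds have a number in an assay on Flp-In-CHO cells for binding affinity to adenosine receptor A3 (Homo sapiens), using Schild analysis; a higher number here means weaker binding, a lower number tighter binding. Compound 1 `COc1cc(Nc2nc(C#N)cc3c(C(C)C)n[nH]c23)cc(OC)c1OC` gives 355 nM; compound 2 `N#Cc1cc2c(-c3ccccc3)n[nH]c2c(Nc2ccccc2)n1` gives 17 nM; compound 3 `COc1cc(Nc2nccc3c(-c4ccccc4)n[nH]c23)cc(OC)c1OC` gives 251 nM. Among these three, compound 3 stands second highest. Its nearest neighbour is compound 1, whose number lies within the scatter of that of compound 3, so no order between the two can be read. Its furthest is compound 2, whose number lies well beyond the scatter on the tighter side.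

Compound 4 `COc1cc(Nc2nc(CNCc3ccccc3)cc3c(-c4ccccc4)n[nH]c23)cc(OC)c1OC` has not yet been measured in this assay. It is reached from compound 3 by (benzylamino)methyl in place of hydrogen on an aromatic carbon, that is, a (benzylamino)methyl group entering on the aromatic carbon of the six-membered ring with one nitrogen, next to the ring nitrogen. Within the data shown here, no pair of measured compounds differs in this single place, so there is no measured step to lean on; the substitutions seen among compounds 1, 2 and 3 change two places at once.

The expectation is therefore a step of a 1.4-fold lower number from compound 3 to compound 4 (0.14 log units; within the scatter) of no size beyond the scatter, with the direction open. In this assay compound 4 is expected to give about 180 nM, estimated between 45 nM and 700 nM.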

Compound 4, dissociation constant: 158 nM
The estimate for compound 4 lay 1.1-fold (0.06 log units) above the measured number, within the range that was stated.
By their numbers in this assay, from the lowest: compound 2; then compounds 4, 3 and 1 (each within the scatter of the next, the first and the last beyond it).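

Working from this assay, the first single-place reading at this position is a 1.6-fold lower number from compound 3 to compound 4 (0.20 log units; within the scatter), for (benzylamino)methyl in place of hydrogen on the aromatic carbon next to the ring nitrogen. The earlier compounds shown here could not show this, since their differences fall in two places at once; here a group of 9 heavy atoms, carrying its own six-membered aromatic ring, enters at this position without a step beyond the scatter. No measurement at hand speaks to the reason for this reading.

A single substituent cannot show whether this tolerance extends to other groups at this position, such as a plain aminomethyl, a benzyloxymethyl or a carboxylic acid. On these data alone, it also remains open whether the same change would read alike on the core of compound 2, which lies well beyond the scatter on the tighter side of compound 3.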